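Ester chain length at adenosine receptor A3: benzyl to phenethyl

The compounds below may be only part of what the source reports. "The series", "measured", "known", "first", "only" and "open" are said of these compounds alone.

Measured so far:
compound 1, `CNc1nc(C#Cc2ccc(Cl)s2)nc2c1ncn2[C@H]1[C@H](O)[C@H](O)[C@]2(C(=O)OC(C)C)C[C@H]12` — 30%
compound 2, `CNc1nc(C#Cc2ccc(Cl)s2)nc2c1ncn2[C@H]1[C@H](O)[C@H](O)[C@]2(C(=O)OCc3ccccc3)C[C@H]12` — 48%

Among the measured compounds shown here, in an assay on cells for displacement of a labelled ligand from adenosine receptor A3 (Mus musculus), read by scintillation counting and radioligand binding, with stated times of 10 min and 90 min, tested at 10 uM (on this read-out lower numbers stand for less inhibition and higher numbers for more inhibition at the one concentration tested (going by the name of the read-out)), compound 2 gives the higher of the two numbers, with compound 1 as its only neighbour, a number 18 percentage points higher from compound 1 to compound 2 (beyond the scatter). Compound 3, `CNc1nc(C#Cc2ccc(Cl)s2)nc2c1ncn2[C@H]1[C@H](O)[C@H](O)[C@]2(C(=O)OCCc3ccccc3)C[C@H]12`, is not yet measured. It differs from compound 2 by benzyl in place of phenyl on a saturated chain carbon bound to an oxygen next to a carbonyl group. For the measured compounds named here, the one measured step, benzyl in place of isopropyl on an oxygen next to a carbonyl group, bears only loosely on this change: it exchanges a different group at the same oxygen, whereas here the benzyl is retained and grows to phenethyl. Going by the values given here, no measured pair shows the effect of one added chain carbon at this place. Among the compounds with values here, with only that indirect precedent, no step beyond the scatter is expected from compound 2 to compound 3 in this assay, a number 3 percentage points lower from compound 2 to compound 3 (within the scatter). Compound 3 is therefore estimated at 45%, within 25% to 65%.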

Compound 3, a percentage reported as inhibition, at one concentration (the size of the read-out at that concentration, not a potency): 3%
The estimate for compound 3 lay 42 percentage points above the measured number; the measured number lies below the stated range.
By their numbers in this assay, from the lowest: compound 3; then compound 1; then compound 2.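

In this assay, the ester position proves sensitive to one added chain carbon: the change from benzyl to phenethyl gives a number 45 percentage points lower from compound 2 to compound 3 (beyond the scatter), a large step that the exchange of isopropyl for benzyl gave no sign of. Phenethyl also falls short of isopropyl, with a number 27 percentage points lower from compound 1 to compound 3 (beyond the scatter), so an aromatic ring on the ester does not by itself go with the higher number: compound 2 and compound 3 both carry a phenyl ring yet lie on opposite sides of compound 1. No measurement at hand accounts for this drop.

From the compounds shown here alone, whether a longer chain such as phenylpropyl stays as low as phenethyl, and how a carboxylic acid or an amide would compare at this place, remains open. Going by these compounds, the potency of these esters also remains open, as the read-out covers one concentration only.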